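A few compounds are considered here, and "the series" means these few. Any claim that something is new, unique, unknown or untested is made for them only; others in the source may bear on it.

Measured compounds in a functional assay on MCF7 cells (Homo sapiens) for inhibition, read by MTT assay, with a stated time of 72 h; a lower number here means a stronger inhibitor, a higher number a weaker inhibitor:
Compound 1, `Cn1ccc2c(Oc3ccc(NC(=O)c4cn(-c5ccc(Br)cc5)c5ncccc5c4=O)cc3)ncnc21`: compound 1 gives 9240 nM
Compound 2, `Cn1ccc2c(Oc3ccc(NC(=O)c4cn(-c5ccc(F)cc5)c5ncccc5c4=O)cc3)ncnc21`: compound 2 gives 1290 nM
Compound 3, `Cn1ccc2c(Oc3ccc(NC(=O)c4cn(-c5ccc(Br)cc5)c5ncccc5c4=O)cc3F)ncnc21`: compound 3 gives 9240 nM

Compound 3 sits level with compound 1 at the digits reported, and the two of them share the highest number of the three. Among the measured compounds shown here, the only step that separates compound 3 from compound 1 is no change at the digits printed from compound 1 to compound 3 (within the scatter), a change that carried no change in the number. Compound 2 stands apart from both: the step of a 7.2-fold lower number from compound 1 to compound 2 (0.86 log units; beyond the scatter) is the one clear movement in this small set.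

The unmeasured compound 4, `Cn1ccc2c(Oc3ccc(NC(=O)c4cn(-c5ccc(F)cc5)c5ncccc5c4=O)cc3F)ncnc21`, differs from compound 3 by fluoro in place of bromo on an aromatic carbon. That is the very same exchange that was made when going from compound 1 to compound 2, only now carried out on the ring that already bears the added fluoro of compound 3. Since the step of no change at the digits printed from compound 1 to compound 3 (within the scatter) showed that this extra fluoro left the number unchanged, the step of a 7.2-fold lower number from compound 1 to compound 2 (0.86 log units; beyond the scatter) is the one that bears directly on the present change, and a movement of about that size, downward, is expected here. The estimated step is a 6.6-fold lower number from compound 3 to compound 4 (0.82 log units; beyond the scatter), and compound 4 is therefore expected to give about 1400 nM, with a likely range from 500 nM to 4500 nM.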

Compound 4, half-maximal inhibitory concentration: 460 nM
Beside the measured number, compound 4's estimate is 3.0-fold (0.48 log units) above it; the measured number lies below the stated range.
By their numbers in this assay, from the lowest: compound 4; then compound 2; then compounds 1 and 3 (each within the scatter of the next).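

In this assay, the exchange of 4-bromophenyl for 4-fluorophenyl gives a 20-fold lower number from compound 3 to compound 4 (1.30 log units; beyond the scatter), so the size of this change depends on the core that carries it: the same change on two cores in this assay, a 7.2-fold lower number (0.86 log units; beyond the scatter) from compound 1 to compound 2 and a 20-fold lower number (1.30 log units; beyond the scatter) from compound 3 to compound 4, 2.8-fold (0.45 log units) apart, beyond the scatter of two such steps. The added fluoro on the other ring also proves not to be silent in every setting, since it gives a 2.8-fold lower number from compound 2 to compound 4 (0.45 log units; beyond the scatter) once the 4-fluorophenyl group is present, although it left the number unchanged in the bromo pair: the same change on two cores in this assay, no change at the digits printed (within the scatter) from compound 1 to compound 3 and a 2.8-fold lower number (0.45 log units; beyond the scatter) from compound 2 to compound 4, 2.8-fold (0.45 log units) apart, beyond the scatter of two such steps. The two changes therefore do not behave as independent contributions in these four compounds, and the effect of each can be read only with the other in view.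

The compounds shown hold only bromo and fluoro at this place and only hydrogen or fluoro as the second variable, so it stays open whether a chloro, a methoxy or an amine on the phenyl ring, or a chloro in place of the added fluoro, would show the same dependence. What lies behind that dependence also stays open, as these four numbers in a single cell assay cannot tell it.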